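Working notes: hydroxy to hydrogen in this series

This account rests on a few compounds, and the source may have more. Where it says the series, first, only, none or still open, it means among the compounds named here.

Measured so far in a functional assay on MGC-803 cells (Homo sapiens) for inhibition, read by MTT assay, with a stated time of 48 h; on this read-out lower numbers stand for stronger inhibition and higher numbers for weaker inhibition:
compound 1 `COc1cc(NCc2ccccc2)cc(OC)c1OC`: > 80000 nM
compound 2 `COc1cc(NCc2cccc(O)c2)cc(OC)c1OC`: 57600 nM
compound 3 `C/C=C/C(=O)N(Cc1ccc(OC)c(O)c1)c1cc(OC)c(OC)c(OC)c1`: 27 nM

In this assay compound 1 reaches only a limit, > 80000 nM, (the limit of > 80000 nM in this assay, at which 1 of the 3 values shown sits). Compound 2 gives 57600 nM and compound 3 gives 27 nM; the difference between the cores of compound 2 and compound 3 is not broken down here. For the measured compounds named here, the one counted step, (hydrogen in place of hydroxy on an aromatic carbon), made an at least 1.3-fold higher number from compound 2 to compound 1 (0.14 log units; that floor lies within the scatter).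

Compound 4 `C/C=C/C(=O)N(Cc1ccc(OC)cc1)c1cc(OC)c(OC)c(OC)c1` carries the same kind of change from compound 3, (hydrogen in place of hydroxy on an aromatic carbon); the places differ in that the hydroxy of compound 3 sits ortho to a methoxy group. The step from compound 3 to compound 4 in this assay is expected to be a 3.0-fold higher number from compound 3 to compound 4 (0.47 log units; beyond the scatter), resting on the small measured step of an at least 1.3-fold higher number from compound 2 to compound 1 (0.14 log units; that floor lies within the scatter). Compound 4 is estimated at 80 nM, expected between 25 nM and 300 nM.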

Compound 4, half-maximal inhibitory concentration: 450 nM
For compound 4 the middle estimate is 5.6-fold (0.75 log units) below the measured one, and the stated range ends below it.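

In this assay, hydrogen in place of hydroxy on the 3-hydroxy-4-methoxyphenyl group gives a 17-fold higher number from compound 3 to compound 4 (1.22 log units; beyond the scatter), a large loss of inhibition on this core. Set side by side, the change on the two cores reads: the same change on two cores in this assay, an at least 1.3-fold higher number (0.14 log units; that floor lies within the scatter) from compound 2 to compound 1 and a 17-fold higher number (1.22 log units; beyond the scatter) from compound 3 to compound 4; the limit leaves it open whether they differ. Compound 1 stands at a limit, > 80000 nM, so the series shows neither that the size of the step carries from one core to the other nor that it differs between them.

Still open, as far as these compounds go, is whether an amine or a fluorine in place of that hydroxy would keep the inhibition seen with compound 3. Also open, from the compounds shown here alone, is whether a methoxy group there would do the same.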